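The compounds below may be only part of what the source reports. "The series", "measured", "known", "first", "only" and "open" are said of these compounds alone.

Measured compounds in an assay on Sf21 cells for inhibition of ubiquitin carboxyl-terminal hydrolase 7 (Homo sapiens), read by spectrophotometry, with stated times of 30 min and 2 h; on this read-out lower numbers stand for stronger inhibition and higher numbers for weaker inhibition:
- compound 1, `COC(=O)c1ccc(N2CCC(O)(Cn3cnc4c(Br)n(C)nc4c3=O)CC2)c(Cl)c1`: 157 nM
- compound 2, `O=c1c2cnn(-c3ccc(F)cc3)c2ncn1CC1(O)CCN(Cc2ccccc2F)CC1`: 9800 nM
- compound 3, `O=c1c2cnn(-c3ccc(F)cc3)c2ncn1CC1(O)CCN(Cc2ccc(Br)cc2)CC1`: 6700 nM

Compound 3 and compound 2 share the same core and differ only in the aryl group on the benzyl carbon; their numbers lie within the scatter of each other, and both stand far from compound 1, whose number in this assay is much lower. Among the compounds with values here, the one step that changes only this aryl group, a 1.5-fold lower number from compound 2 to compound 3 (0.17 log units; within the scatter), shows that swapping one halogenated phenyl for another at this position made no difference beyond the scatter.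

Compound 4, `O=c1c2cnn(-c3ccc(F)cc3)c2ncn1CC1(O)CCN(Cc2ccc(Cl)cc2Cl)CC1`, differs from compound 3 in the same place: 2,4-dichlorophenyl in place of 4-bromophenyl on a saturated chain carbon bound to an amine nitrogen in a ring. Within the data shown here, the only comparable step on record is that from compound 2 to compound 3, so the step to compound 4 is expected to be small as well, with no clear direction. Compound 4 is therefore estimated at 5500 nM in this assay, with a likely range from 2000 nM to 15000 nM. The implied step a 1.2-fold lower number from compound 3 to compound 4 (0.09 log units; within the scatter) is expected to stay within the scatter.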

Compound 4, half-maximal inhibitory concentration: 3300 nM
Estimate against measurement, compound 4: 1.7-fold (0.22 log units) above; the range from low to high includes it.
By their numbers in this assay, from the lowest: compound 1; then compound 4; then compounds 3 and 2 (each within the scatter of the next).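

In this assay, the aryl group on the saturated chain carbon bound to the ring amine nitrogen now proves able to shift the number: a 2.0-fold lower number from compound 3 to compound 4 (0.31 log units; beyond the scatter) lies beyond the scatter, as does a 3.0-fold lower number from compound 2 to compound 4 (0.47 log units; beyond the scatter), while the swap between the two singly halogenated aryl groups, a 1.5-fold lower number from compound 2 to compound 3 (0.17 log units; within the scatter), did not. Within the data shown here, both new steps are modest, and they place 2,4-dichlorophenyl, the only aryl group here with two halogen atoms, ahead of both 4-bromophenyl and 2-fluorophenyl at this place. No evidence on hand explains this difference.

The compounds shown leave open whether a phenyl bearing a single chlorine would give the same step, or whether both chlorine atoms are needed. They also leave open how an unsubstituted phenyl, a methoxyphenyl or a carboxylic acid on the aryl ring would read at this place.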